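From substituted phenyl to plain phenyl on the carbonyl

The compounds below may be only part of what the source reports. "The series", "measured", "known", "first", "only" and "open" are said of these compounds alone.

Measured in a functional assay on Malme-3M cells (Homo sapiens) for inhibition, read by sulforhodamine B assay, with a stated time of 48 h; a lower number here means a stronger inhibitor of growth, a higher number a weaker inhibitor of growth:
Compound 1 `COc1cc(-c2nn(-c3cccc(NC(=O)Nc4cccc(C(F)(F)F)c4)c3)cc2-c2ccncc2)ccc1Cl`: 1050 nM
Compound 2 `COc1cc(-c2nn(-c3cccc(NC(=O)c4ccc(Cl)c(C(F)(F)F)c4)c3)cc2-c2ccncc2)ccc1Cl`: 1180 nM

Going by the values given here, the only measured step is a 1.1-fold higher number from compound 1 to compound 2 (0.05 log units; within the scatter), so compound 2 stands level with compound 1. Compound 3 `COc1cc(-c2nn(-c3cccc(NC(=O)c4ccccc4)c3)cc2-c2ccncc2)ccc1Cl` has phenyl in place of 4-chloro-3-(trifluoromethyl)phenyl on a carbonyl carbon. Among the compounds with values here, the measured step bears on this only loosely: compound 1 and compound 2 both carry trifluoromethyl, and no measured compound lacks it. With that thin evidence, a modestly higher number in this assay is expected, starting from compound 2 at 1180 nM. The expected change is a 2.1-fold higher number from compound 2 to compound 3 (0.33 log units; beyond the scatter). Compound 3 is estimated at 2500 nM, with a range of 900 nM to 7500 nM.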

Compound 3, concentration for 50% growth inhibition: 537 nM
For compound 3 the middle estimate is 4.7-fold (0.67 log units) above the measured one; measured number below the stated range.
By their numbers in this assay, from the lowest: compounds 3, 1 and 2 (each within the scatter of the next, the first and the last beyond it).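

In this assay, the group on this carbonyl carbon does not need its substituents: replacing 4-chloro-3-(trifluoromethyl)phenyl with plain phenyl gives a 2.2-fold lower number from compound 2 to compound 3 (0.34 log units; beyond the scatter). Replacing (3-(trifluoromethyl)phenyl)amino with phenyl gives a 2.0-fold lower number from compound 1 to compound 3 (0.29 log units; within the scatter), so trifluoromethyl is not required for activity at this level. Nothing measured here explains why removing these groups helps.

As far as these compounds go, what remains open is how chlorine alone or trifluoromethyl alone on the phenyl would behave. It is also unknown whether an amine or a carboxylic acid there would shift the number further.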